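This account rests on a few compounds, and the source may have more. Where it says the series, first, only, none or still open, it means among the compounds named here.

Measured so far
Compound 1 `COc1ccc(/C=C/C(=O)NC(CCN(C)C)c2ccc(C)cc2)cc1` — 2000 nM
Compound 2 `COc1ccc(/C=C/C(=O)NC(CCN(C)C)c2ccc(Cl)cc2)cc1` — 513 nM

Compound 1 `COc1ccc(/C=C/C(=O)NC(CCN(C)C)c2ccc(C)cc2)cc1` and compound 2 `COc1ccc(/C=C/C(=O)NC(CCN(C)C)c2ccc(Cl)cc2)cc1` are the two compounds with numbers in a functional assay on NIH3T3 cells for agonist activity at Urotensin-2 receptor (Homo sapiens), with a stated time of 5 days; on this read-out lower numbers stand for an effect already at smaller amounts and higher numbers for an effect only at larger amounts of compound; compound 1 gives 2000 nM, compound 2 gives 513 nM. For the measured compounds named here, the one measured step, a 3.9-fold lower number from compound 1 to compound 2 (0.59 log units; beyond the scatter), is the only step. Compound 2 therefore holds the lowest number of the two, with compound 1 the nearer (and only) neighbour.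

Compound 3 `CN(C)CCC(NC(=O)/C=C/c1ccccc1)c1ccc(Cl)cc1` differs from compound 2 by hydrogen in place of methoxy on an aromatic carbon. Going by the values given here, no measured step touches the methoxy position; the step from compound 1 to compound 2 concerns a different ring and does not inform this change. There is thus no basis from the series for a directional expectation, and the range must stay wide. Removing the methoxy is taken, by default, as leaving the number at or somewhat above that of compound 2, so a step of a 2.9-fold higher number from compound 2 to compound 3 (0.47 log units; beyond the scatter) is estimated. Compound 3 is expected to give about 1500 nM in this assay, within a range from 300 nM to 8000 nM.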

Compound 3, half-maximal effective concentration: 427 nM
Compound 3: the middle estimate sits 3.5-fold (0.55 log units) above what was measured; measured number inside the range.
By their numbers in this assay, from the lowest: compounds 3 and 2 (each within the scatter of the next); then compound 1.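

In this assay the step on the 4-methoxyphenyl to phenyl change, hydrogen in place of methoxy on an aromatic carbon para to a large group, comes to a 1.2-fold lower number from compound 2 to compound 3 (0.08 log units; within the scatter) and so does not separate the two compounds. For this pair, which shares the chloro group on the other ring, the methoxy group is therefore not required to hold the number at the level of compound 2, and the position tolerates the loss of its 2 heavy atoms and 1 hydrogen-bond acceptor without a change beyond the scatter. No measurement at hand explains why the two compounds stand level.

For the compounds shown here, whether the same replacement reads the same way with methyl instead of chloro on the other ring remains open, since the single pair here carries chloro only. Also open, as far as these compounds go, is how this position responds to groups other than methoxy and hydrogen, such as fluoro, hydroxy, an amine or a carboxylic acid, which would show whether any substituent here can move the number beyond the scatter.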